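A few compounds are considered here, and "the series" means these few. Any claim that something is new, unique, unknown or untested is made for them only; others in the source may bear on it.

Three compounds have been measured in an in vitro functional assay on HEK ts201 cells for antagonist activity at Neuronal acetylcholine receptor; alpha4/beta2 (Homo sapiens), read by fluorescence and calcium flux; a higher number here means a weaker inhibitor, a lower number a stronger inhibitor:

Compound 1 `c1ccc(CCCN2CCCC(COCc3cn(Cc4ccccc4-c4ccccc4)nn3)C2)cc1`: 2880 nM
Compound 2 `COc1ccc(OCCCCCN2CCCC(COC(=O)c3ccccc3N3C(=O)CC(C)C3=O)C2)cc1OC`: 8320 nM
Compound 3 `O=C(Nc1ccccn1)c1ccccc1-c1ccccc1`: 13600 nM

Among these three numbers, compound 2 holds the second highest. Its nearest neighbour is compound 3, whose number sits within the usual scatter of the measurement, so the two cannot be told apart on these data. Its furthest neighbour is compound 1, whose lower number lies beyond the scatter, so compound 1 is the clearly stronger inhibitor of the pair.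

Compound 4 `CC1CC(=O)N(c2ccccc2C(=O)OCC2CCCN(CCCCOc3ccc(Cl)c(Cl)c3)C2)C1=O` has not yet been measured. It differs from compound 2 in one place: 3,4-dichlorophenoxy in place of (3,4-dimethoxyphenoxy)methyl on a saturated chain carbon, four bonds along the chain from an amine nitrogen in a ring. Among the measured compounds shown here, no pair of measured compounds differs in a single place, so no measured step shows what a change of this kind does here. The change is a moderate one on the outer end of the chain, and the expectation is a step of modest size in either direction, most likely not far beyond the scatter. The estimate for compound 4 is 5500 nM, with a range from 1800 nM to 17000 nM. This corresponds to an expected step of a 1.5-fold lower number from compound 2 to compound 4 (0.18 log units; within the scatter).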

Compound 4, half-maximal inhibitory concentration: 12300 nM
Beside the measured number, compound 4's estimate is 2.2-fold (0.35 log units) below it; measured number inside the range.
By their numbers in this assay, from the lowest: compound 1; then compounds 2, 4 and 3 (each within the scatter of the next).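

Read in this assay the exchange of (3,4-dimethoxyphenoxy)methyl for 3,4-dichlorophenoxy gives a 1.5-fold higher number from compound 2 to compound 4 (0.17 log units; within the scatter) and so leaves the two compounds impossible to tell apart on these data. Among the compounds shown here, this is the first measured step that changes only one place in this set, and it shows that at this position, on a saturated chain carbon four bonds along the chain from an amine nitrogen in a ring, the group can go from 12 heavy atoms to 9 and from 3 hydrogen-bond acceptors to 1 without a change that the measurement can separate from its scatter. No other measurement is at hand that could explain this result.

As far as these compounds go, whether a different group at this position, such as a plain phenyl, a carboxylic acid or an amine, would move the number beyond the scatter stays open. For the compounds shown here, whether the same exchange would behave alike on another core, such as that of compound 1, is also open, as no single-place step links that compound to these two.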